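Bromo for nitro in a dienone series: a cytotoxicity estimate

A few compounds are considered here, and "the series" means these few. Any claim that something is new, unique, unknown or untested is made for them only; others in the source may bear on it.

Measured so far:
compound 1, `CC1=C(/C=C/C(=O)/C=C/c2ccc(F)cc2)C(C)(C)CCC1`: 7400 nM
compound 2, `CC1=C(/C=C/C(=O)/C=C/c2ccccc2[N+](=O)[O-])C(C)(C)CCC1`: 13500 nM

Of the compounds shown here, two sharing one core have been tested in a functional assay on IMR-32 cells (Homo sapiens) for cytotoxicity, read by sulforhodamine B assay, with a stated time of 48 h; on this read-out lower numbers stand for stronger inhibition and higher numbers for weaker inhibition. Compound 1 gives 7400 nM in this assay. Compound 2 gives 13500 nM, the higher of the two numbers, but its gap to compound 1 lies within the scatter of this kind of measurement, so the two are not told apart on these data.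

Compound 3, `CC1=C(/C=C/C(=O)/C=C/c2ccccc2Br)C(C)(C)CCC1`, has not yet been measured. It differs from compound 2 in one place: bromo in place of nitro on an aromatic carbon, ortho to a large group. For the measured compounds named here, no step between measured compounds is available for this change, so there is no directly comparable precedent here.

The expected step is a 1.5-fold lower number from compound 2 to compound 3 (0.18 log units; within the scatter), a move that stays within the scatter rather than a clear shift in either direction. Compound 3 is therefore estimated at 9000 nM in this assay, with a likely range from 3000 nM to 27000 nM.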

Compound 3, half-maximal inhibitory concentration: 16300 nM
The estimate for compound 3 lay 1.8-fold (0.26 log units) below the measured number; the range from low to high includes it.
By their numbers in this assay, from the lowest: compounds 1, 2 and 3 (each within the scatter of the next, the first and the last beyond it).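

In this assay, bromo in place of nitro on an aromatic carbon, ortho to a large group, gives a 1.2-fold higher number from compound 2 to compound 3 (0.08 log units; within the scatter). At this position, then, a single bromine atom and a nitro group with its three heavy atoms and two hydrogen-bond acceptors are not told apart by this read-out. The change of 2-bromophenyl in place of 4-fluorophenyl gives a 2.2-fold higher number from compound 1 to compound 3 (0.34 log units; beyond the scatter), a modest step and the first one in this small set that lies beyond the scatter, but it alters both the halogen and its place on the ring, and the numbers cannot assign it to either. Nothing measured here speaks to the reason for these numbers.

From the compounds shown here alone, whether a 2-fluorophenyl or a 4-bromophenyl compound would read closer to compound 1 or to compound 3 stays open, and such a pair would be needed to separate the halogen from its place. Also open, going by these compounds, is how an amine or a carboxylic acid on that same aromatic carbon would read in this assay, since only nitro and bromo have been seen there.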